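Compound 3 to compound 4: an open step

The source may hold more compounds than are shown below. What is called first, only, known or untested is meant among the compounds shown, and "the series" means these compounds.

Measured in an ADME assay on RAW264.7 cells (Mus musculus) for cytotoxicity, read by WST assay; on this read-out higher numbers stand for lower toxicity in this test and lower numbers for higher toxicity in this test:
Compound 1 `O=C(c1ccc(CN2C(=O)c3ccccc3S2(=O)=O)cc1)N1CCCCC1`: 69200 nM
Compound 2 `CC(C)(C)OC(=O)c1ccc(CN2C(=O)c3ccccc3S2(=O)=O)cc1`: > 100000 nM, a limit and not a number
Compound 3 `CC(C)(C)OC(=O)NC(=O)c1ccc(CN2C(=O)c3ccccc3S2(=O)=O)cc1`: > 100000 nM, a limit and not a number

Compound 3 thus stands on (the limit of > 100000 nM in this assay, at which 2 of the 3 values shown sit). Compound 4 `CC(=O)N(Cc1ccco1)C(=O)c1ccc(CN2C(=O)c3ccccc3S2(=O)=O)cc1` carries acetyl((furan-2-yl)methyl)amino in place of (tert-butoxycarbonyl)amino on a carbonyl carbon whose other neighbours are: aromatic carbon (acetyl((furan-2-yl)methyl)amino in place of (tert-butoxycarbonyl)amino on a carbonyl carbon). Three measured steps exchange the group at that same carbonyl carbon: there is an at least 1.4-fold higher number from compound 1 to compound 2 (0.15 log units; that floor lies within the scatter), there is an at least 1.4-fold higher number from compound 1 to compound 3 (0.15 log units; that floor lies within the scatter), and there is a step that the two limits leave unreadable from compound 2 to compound 3. None of them shows a change beyond the scatter, so they offer no firm size for a new group. In this assay, going by these compounds, no step beyond the scatter is therefore expected, and the direction stays open. A reading like that of compound 1, 69200 nM, is one expected outcome. A further limit seems about as likely. The expected change is an at least 1.1-fold lower number from compound 3 to compound 4 (0.04 log units; that floor lies within the scatter). For compound 4 the estimated value is 90000 nM, with an expected range from 35000 nM to 200000 nM.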

Compound 4, concentration lethal to 50% of the cells: > 100000 nM
Compound 4: a limit, no number; the forecaster's own chance of this, stated with the estimate: 55%; middle value at least 1.1-fold (0.04 log units) away from the limit.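

In this assay, the change to acetyl((furan-2-yl)methyl)amino brings a five-membered aromatic ring to this carbonyl carbon and removes the hydrogen-bond donor of compound 3, yet compound 4 still gives only a limit and not a number. Within the data shown here, its steps to compound 2 and compound 3 cannot be read, and the one step that can be read is an at least 1.4-fold higher number from compound 1 to compound 4 (0.15 log units; that floor lies within the scatter), so this group, like the two before it, shows no change beyond the scatter. Compound 4 now shares one limit with compound 2 and compound 3: the limit of > 100000 nM in this assay, at which 3 of the 4 values shown sit.

The compounds shown leave open whether any group on this carbonyl carbon can move the reading beyond the scatter from that of compound 1. A carboxylic acid or a small amine such as dimethylamino at this place would test that, and the core of compound 1 itself stays unexplored here, with every change shown falling on this one carbon.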